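The source may report more compounds than this note shows. Statements on the series, on what has been measured and on what is new or still open speak of the compounds shown alone.

Working notes on the series around compound 1 `C/C=C1/[C@H](O[C@@H]2O[C@H](CO)[C@@H](O)[C@H](O)[C@H]2O)OC=C(C(=O)OC)[C@H]1CC(=O)OCc1ccco1`. In a functional assay on SK-BR-3 cells (Homo sapiens) for antiproliferative activity, read by MTT assay, with a stated time of 72 h (on this read-out lower numbers stand for stronger inhibition and higher numbers for weaker inhibition), compound 1 gives > 15000 nM, which is a limit of the assay rather than a number. Two further members carry the peracetylated sugar. Compound 2 `C/C=C1/[C@H](O[C@@H]2O[C@H](COC(C)=O)[C@@H](OC(C)=O)[C@H](OC(C)=O)[C@H]2OC(C)=O)OC=C(C(=O)OC)[C@H]1CC(=O)OCCCCCCCCCCCCCCC`, with the long saturated ester chain, gives 3810 nM in this assay. Compound 3 `C/C=C1/[C@H](O[C@@H]2O[C@H](COC(C)=O)[C@@H](OC(C)=O)[C@H](OC(C)=O)[C@H]2OC(C)=O)OC=C(C(=O)OC)[C@H]1CC(=O)SCCC`, the thioester, gives > 15000 nM in this assay, again a limit. Among the measured compounds shown here, none of these three differ from another in one place only, so no single step between measured compounds can be read off. For the measured compounds named here, what can be said of compound 1 is where it stands: at the limit of > 15000 nM in this assay, at which 2 of the 3 values shown sit, together with compound 3, while compound 2 is the only member with a numerical value.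

The next compound, compound 4 `C/C=C1/[C@H](O[C@@H]2O[C@H](CO)[C@@H](O)[C@H](O)[C@H]2O)OC=C(C(=O)OC)[C@H]1CC(=O)OCc1ccccc1`, keeps the free sugar and the core of compound 1 and changes the ester end (phenyl in place of furan-2-yl on a saturated chain carbon bound to an oxygen next to a carbonyl group). The change is small and exchanges one aromatic ring for another of similar size at the same place. With compound 1 sitting at the limit, no step beyond the scatter is expected in either direction in this assay, and the most likely outcome is a further limit. Compound 4 is therefore estimated at 20000 nM, with a range from 7000 nM to 60000 nM. The expected step that the limit leaves unreadable from compound 1 to compound 4 is none beyond the scatter.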

Compound 4, half-maximal inhibitory concentration: > 15000 nM
Compound 4 ended at the assay's limit (the forecaster's own chance of this, stated with the estimate: 80%); the middle value does not contradict the limit.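

In this assay compound 4 gives > 15000 nM, a limit of the assay and not a number. Among the compounds shown here, compound 1 and compound 4 both sit at a limit, so no step between them can be read: the limit of > 15000 nM in this assay, at which 3 of the 4 values shown sit. The compounds shown leave open whether phenyl and furan-2-yl differ at all at this place.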